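Relocating the Hydroxy Group from Compound 2 to Compound 4

A few compounds are considered here, and "the series" means these few. Any claim that something is new, unique, unknown or untested is made for them only; others in the source may bear on it.

Measured in a functional assay on MCF7 cells (Homo sapiens) for cytotoxicity, read by MTT assay, with a stated time of 48 h; on this read-out lower numbers stand for stronger inhibition and higher numbers for weaker inhibition:
- Compound 1 `O=C1/C(=C\c2ccccc2)S/C(=N/c2ccccc2)N1Cc1ccncc1` gives 26400 nM
- Compound 2 `O=C1/C(=C\c2ccc(O)cc2)S/C(=N/c2ccccc2)N1Cc1ccncc1` gives 18900 nM
- Compound 3 `COc1ccc(OC)c(/C=C2/S/C(=N/c3ccccc3)N(Cc3ccncc3)C2=O)c1` gives 37000 nM

Compound 2 has the lowest of the three numbers, yet the step of a 1.4-fold lower number from compound 1 to compound 2 (0.15 log units; within the scatter) and the step of a 2.0-fold higher number from compound 2 to compound 3 (0.29 log units; within the scatter) both sit within the scatter, so the three compounds cannot be ranked. Compound 4 `O=C1/C(=C\c2cccc(O)c2)S/C(=N/c2ccccc2)N1Cc1ccncc1` differs from compound 2 only in how its atoms are joined: 3-hydroxyphenyl in place of 4-hydroxyphenyl on a double-bonded chain carbon bound to a double-bonded ring carbon. Within the data shown here, the steps that bear on this are a 1.4-fold lower number from compound 1 to compound 2 (0.15 log units; within the scatter), where a hydroxy was added, and a 2.0-fold higher number from compound 2 to compound 3 (0.29 log units; within the scatter), where the ring substituents were exchanged; neither moved the number beyond the scatter. Among the measured compounds shown here, no measured step moves a hydroxy around the ring, so a step of comparable small size is expected, a 1.1-fold higher number from compound 2 to compound 4 (0.05 log units; within the scatter), with no clear direction. Compound 4 is therefore estimated at 21000 nM, between 10000 nM and 42000 nM.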

Compound 4, half-maximal inhibitory concentration: 43600 nM
Compound 4: middle estimate off by 2.1-fold (0.32 log units), on the low side; measured number outside the range, above it.
By their numbers in this assay, from the lowest: compounds 2, 1, 3 and 4 (each within the scatter of the next, the first and the last beyond it).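

Moving the hydroxy on this ring is the first change in this assay to go beyond the scatter, with a 2.3-fold higher number from compound 2 to compound 4 (0.36 log units; beyond the scatter) as its step. Adding a hydroxy to the phenyl of compound 1 at the 3-hydroxyphenyl site gives only a 1.7-fold higher number from compound 1 to compound 4 (0.22 log units; within the scatter) and exchanging the 2,5-dimethoxyphenyl gives only a 1.2-fold higher number from compound 3 to compound 4 (0.07 log units; within the scatter), so both stay within the scatter and here the hydroxy's site matters more than its presence. Nothing available explains this shift. Going by these compounds, whether an amine or a carboxylic acid on this ring would act like the hydroxy remains open.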